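Adding a Second Fluoro to an Acyl Urea Hydrazone

A few compounds are considered here, and "the series" means these few. Any claim that something is new, unique, unknown or untested is made for them only; others in the source may bear on it.

Compound 1 `CN(C(=O)NC(=O)c1ccccc1F)c1nc(C(F)(F)F)c(C(=O)N/N=C/c2cc(C(F)(F)F)cc(C(F)(F)F)c2)s1`: 4.98 ug/mL
Compound 2 `Cc1nc(N(C)C(=O)NC(=O)c2c(F)cccc2F)sc1C(=O)N/N=C/c1ccccc1C(F)(F)F`: 6.51 ug/mL

Of the compounds shown here, two have been measured in a functional assay on HeLa cells (Homo sapiens) for inhibition, read by MTT assay, with a stated time of 72 h; on this read-out lower numbers stand for stronger inhibition and higher numbers for weaker inhibition. Compound 1 gives 4.98 ug/mL. Compound 2 gives 6.51 ug/mL. Among the measured compounds shown here, the two values lie within the usual scatter of each other, so neither compound can be called the more potent of the pair on these numbers, and no single structural step between them can be read off, since they differ in more than one place.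

Compound 3 `CN(C(=O)NC(=O)c1c(F)cccc1F)c1nc(C(F)(F)F)c(C(=O)N/N=C/c2cc(C(F)(F)F)cc(C(F)(F)F)c2)s1` has not been measured. It differs from compound 1 in one place: fluoro in place of hydrogen on an aromatic carbon. The rest of the molecule is unchanged. For the measured compounds named here, the only other compound on record with a 2,6-difluorophenyl group is compound 2, and its value sits close to that of compound 1. Compound 2 also differs from compound 1 in other places, and that comparison carries little weight.

Going by the values given here, with no measured step to build on, the expected move in this assay from compound 1 to compound 3 is small, no further than the usual scatter, in either direction: a 1.1-fold lower number from compound 1 to compound 3 (0.04 log units; within the scatter). Compound 3 is therefore expected to give 4.5 ug/mL, with a likely range from 2 ug/mL to 10 ug/mL.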

Compound 3, half-maximal inhibitory concentration: 5.62 ug/mL
Beside the measured number, compound 3's estimate is 1.2-fold (0.10 log units) below it, within the range that was stated.
By their numbers in this assay, from the lowest: compounds 1, 3 and 2 (each within the scatter of the next).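

In this assay, among the compounds shown here, replacing the 2-fluorophenyl group of compound 1 with the 2,6-difluorophenyl group of compound 3 gives a 1.1-fold higher number from compound 1 to compound 3 (0.05 log units; within the scatter) and this is the first comparison here in which only one place differs. At this position on the ring, ortho to a large group, adding a second fluoro therefore produces no difference that this read-out can separate from the ordinary variation between repeated measurements, at least on the core of compound 1. No measurement of any other kind bears on this result, so the step gives a size but no explanation.

Fluoro is the only group tested in this single-place comparison, so a chloro, a methoxy group or an amine at the same position could give a different answer, and a plain phenyl group with no fluoro at all would show whether the first fluoro matters any more than the second. Going by these compounds, it also remains open whether the same step would look alike on a different core, such as one carrying a methyl group in place of the trifluoromethyl group.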